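Compound 4: One Exchange, Starting From a Limit

The source may hold more compounds than are shown below. What is called first, only, known or untested is meant among the compounds shown, and "the series" means these compounds.

In an ADME assay on B16-F10 cells (Mus musculus) for cytotoxicity, read by CCK-8 assay, with a stated time of 16 h (a higher number here means a weaker inhibitor, a lower number a stronger inhibitor), three compounds sharing one core have been read so far, and none of them gives an exact number. Compound 1 (`COc1ccc(C2=[N+]3C(=Nc4c(-c5ccccc5)c5c(n4[B-]3(F)F)-c3ccc(OCC(=O)O)cc3CC5)C(c3ccccc3)=C2I)cc1`) gives > 50000 nM, which is a limit. Compound 2 (`COc1ccc(C2=[N+]3C(=Nc4c(-c5ccccc5)c5c(n4[B-]3(F)F)-c3ccc(OCC(=O)N[C@@H](CC(=O)O)C(=O)O)cc3CC5)C(c3ccccc3)=C2I)cc1`) gives > 250000 nM, which is also a limit. Compound 3 (`COc1ccc2c(c1)CCc1c(-c3ccccc3)c3n(c1-2)[B-](F)(F)[N+]1=C(c2ccc(OCC(=O)O)cc2)C(I)=C(c2ccccc2)C1=N3`) gives > 50000 nM, and this too is a limit. That places compound 3 at the limit of > 50000 nM in this assay, at which 2 of the 3 values shown sit, so it offers no exact number to start from.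

The move to compound 4 (`COc1ccc2c(c1)CCc1c(-c3ccccc3)c3n(c1-2)[B-](F)(F)[N+]1=C(c2ccc(OCC(=O)N[C@@H](CC(=O)O)C(=O)O)cc2)C(I)=C(c2ccccc2)C1=N3`) is (1,2-dicarboxyethyl)amino in place of hydroxy on a carbonyl carbon. The same exchange has been measured once, as a step that the two limits leave unreadable from compound 1 to compound 2. That single precedent therefore gives no size to carry over, though it shows no gain in inhibition either. Compound 2 ends at the limit of > 250000 nM in this assay, at which 1 of the 3 values shown sits, and compound 4 is expected to be reported as a limit of that kind rather than as a number. The estimated change is a step that the limit leaves unreadable from compound 3 to compound 4, with no stronger inhibition expected. The expected value for compound 4 is 250000 nM, with an estimated range from 100000 nM to 500000 nM.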

Compound 4, half-maximal inhibitory concentration in the B16-F10 assay: > 250000 nM
Compound 4 was reported as a limit; the forecaster's own chance of this, stated with the estimate: 90%; the middle value lies on the limit itself.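

In the B16-F10 assay compound 3 gives > 50000 nM, which is a limit. In the B16-F10 assay compound 4 gives > 250000 nM, which is also a limit, so no step can be read between them. The compounds shown leave open whether (1,2-dicarboxyethyl)amino in place of hydroxy on a carbonyl carbon changes the reading in the B16-F10 assay at all; compound 1, compound 2, compound 3 and compound 4 give no exact number there. In a physicochemical assay for solubility, in phosphate buffer (on this read-out higher numbers stand for higher solubility and lower numbers for lower solubility), compound 3 gives 21800 nM and compound 4 gives 115000 nM.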